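This account rests on a few compounds, and the source may have more. Where it says the series, first, only, none or still open, it means among the compounds named here.

In a functional assay on NCI-H460 cells (Homo sapiens) for cytotoxicity, read by MTT assay, with a stated time of 48 h (on this read-out lower numbers stand for stronger inhibition and higher numbers for weaker inhibition), three compounds sharing one core have been tested, and none of them yields a number. Compound 1 (`COc1ccc(/C=C/C(=O)/C=C/c2cc3ccccc3nc2Oc2ccc(Br)cc2)cc1`) gives > 10000 nM as its result, which is a limit of the assay. Compound 2 (`COc1ccc(/C=C/C(=O)/C=C/c2cc3ccccc3nc2Oc2ccc(Br)cc2)c(OC)c1`) gives > 10000 nM as its result, again a limit. Compound 3 (`COc1ccc(/C=C/C(=O)/C=C/c2cc3ccccc3nc2Oc2ccc(Br)cc2)cc1OC`) gives > 10000 nM as its result, and this too is a limit. All three therefore stand at the same mark (the limit of > 10000 nM in this assay, at which 3 of the 3 values shown sit) and cannot be ranked.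

The next compound is compound 4 (`COc1ccc(/C=C/C(=O)/C=C/c2cc3ccccc3nc2Oc2cccc(Cl)c2)cc1OC`), which carries 3-chlorophenyl in place of 4-bromophenyl on an oxygen on an aromatic ring and is otherwise the same as compound 3. Within the data shown here, none of the measured steps touches this group, and none has a readable size. The data show a step that the two limits leave unreadable from compound 1 to compound 2 and a step that the two limits leave unreadable from compound 1 to compound 3 and also a step that the two limits leave unreadable from compound 2 to compound 3 among the methoxy changes. No size can be carried over from them, so the expectation rests on compound 3 and its limit > 10000 nM alone. No step beyond the scatter is expected in either direction in this assay, and the expected change is a step that the limit leaves unreadable from compound 3 to compound 4 on this reading. For compound 4 the estimate is 12000 nM with an expected range from 3000 nM to 30000 nM and a fair chance of another limit.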

Compound 4, half-maximal inhibitory concentration: > 10000 nM
Compound 4 ended at the assay's limit; the forecaster's own chance of this, stated with the estimate: 65%; the middle value does not contradict the limit.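

Compound 4 gives > 10000 nM in this assay, and this is a limit of the assay. Compound 3 also stands at a limit, so no step can be read between compound 3 and compound 4: the limit of > 10000 nM in this assay, at which 4 of the 4 values shown sit.

The compounds shown leave open whether 3-chlorophenyl in place of 4-bromophenyl changes the result at all, and how any of the four ranks against the others.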